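This account rests on a few compounds, and the source may have more. Where it says the series, first, only, none or still open, it means among the compounds named here.

Among the measured compounds shown here, compound 2, `O=C(Nn1c(-c2cccc([N+](=O)[O-])c2)nc2c(-c3ccco3)n[nH]c2c1=O)c1cccnc1`, is one of two compounds so far run in a functional assay on SK-OV-3 cells (Homo sapiens) for cytotoxicity, read by sulforhodamine B assay, with a stated time of 2 days, tested at 100 uM; on this read-out higher numbers stand for more inhibition at the one concentration tested (going by the name of the read-out) and lower numbers for less inhibition; in that assay compound 2 gives -0.61%, the lower of the two numbers. For the measured compounds named here, its only neighbour, compound 1, `O=C(Nn1c(-c2cccc([N+](=O)[O-])c2)nc2c(-c3ccc(Cl)cc3)n[nH]c2c1=O)c1cccnc1`, gives the higher inhibition in this assay, and compound 1 gives 30.2%. Going by the values given here, the single step measured between them, a number 30.8 percentage points lower from compound 1 to compound 2 (beyond the scatter), replaced the group on the aromatic carbon of the shared core with furan-2-yl, and that furan-2-yl remains in place in what follows. Compound 3, `COc1cccc(-c2nc3c(-c4ccco4)n[nH]c3c(=O)n2NC(=O)c2cccnc2)c1`, is the next compound, and it differs from compound 2 at a different site: methoxy in place of nitro on an aromatic carbon. No measured step touches the 3-nitrophenyl, so there is no direct precedent for this change; what the numbers shown do say is that compound 2 already sits at the bottom of the range. The step that compound 3 is expected to make is a number 4.6 percentage points higher from compound 2 to compound 3 (within the scatter), which should not rise beyond the scatter. The estimate for compound 3 is accordingly 4%, within a range from -10% to 22%.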

Compound 3, a percentage reported as inhibition, at one concentration (the size of the read-out at that concentration, not a potency): 25%
Compound 3: the middle estimate sits 21 percentage points below what was measured; the measured number lies above the stated range.
By their numbers in this assay, from the lowest: compound 2; then compounds 3 and 1 (each within the scatter of the next).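

In this assay, the step of a number 25.6 percentage points higher from compound 2 to compound 3 (beyond the scatter) shows that the site meta to a large group on the six-membered aromatic ring is not silent: with furan-2-yl held in place, methoxy in place of nitro moves the number beyond the scatter. Among the compounds shown here, compound 2 therefore does not owe its place at the bottom of the range to the furan-2-yl alone, since the 3-nitrophenyl to 3-methoxyphenyl change, at a different site from the one altered in the step of a number 30.8 percentage points lower from compound 1 to compound 2 (beyond the scatter), also shifts the read-out by more than the scatter. No measurement on hand explains why this exchange of groups changes the read-out.

The compounds shown leave open whether the rise belongs to the methoxy itself or to the loss of the nitro, a question that plain hydrogen, an amine or a longer chain such as ethoxy at the same place would bear on. They also leave open whether the same change gives a step of similar size when 4-chlorophenyl, rather than furan-2-yl, sits on the shared core.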